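Thiourea-bearing analogue of a weakly active thiophene amide series

This account rests on a few compounds, and the source may have more. Where it says the series, first, only, none or still open, it means among the compounds named here.

Measured compounds in a functional assay on HeLa cells (Homo sapiens) for antiproliferative activity, with a stated time of 24 h; a lower number here means a stronger inhibitor, a higher number a weaker inhibitor:
compound 1 `Cc1ccccc1CN1CCc2c(sc(NC(=O)c3ccccc3Cl)c2C(N)=O)C1`: > 50000 nM
compound 2 `NC(=O)c1c(NC(=O)c2ccccc2Cl)sc2c1CCN(Cc1ccc(Cl)cc1)C2`: > 50000 nM
compound 3 `NC(=O)c1c(NC(=O)c2ccccc2Cl)sc2c1CCN(C(=S)Nc1ccccc1-c1ccccc1)C2`: 24000 nM

Compound 1 stands only at a limit of this assay; its value > 50000 nM is a limit and not a number. Compound 2 likewise gives only a limit, > 50000 nM. Within the data shown here, of the three values shown, two sit at the same limit (the limit of > 50000 nM in this assay, at which 2 of the 3 values shown sit), so compound 1 cannot be placed against compound 2, and the one step between them, a step that the two limits leave unreadable from compound 1 to compound 2, is unreadable. Among the measured compounds shown here, compound 3 is the only one with a measured number, 24000 nM, and it is also the only one carrying a group of the same kind as the one entering compound 4.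

The compound to be measured is compound 4 `COc1ccc(NC(=S)N2CCc3c(sc(NC(=O)c4ccccc4Cl)c3C(N)=O)C2)cc1`. The change from compound 1 is a group of 11 heavy atoms (8 carbon, 1 nitrogen, 1 oxygen, 1 sulfur; one six-membered aromatic ring of carbon only) in place of a group of 8 heavy atoms (8 carbon; one six-membered aromatic ring of carbon only), on an amine nitrogen in a ring. For the measured compounds named here, no measured step bears directly on it: the step from compound 1 to compound 2 is unreadable, and no step is recorded between compound 1 and compound 3. On the limited evidence that compound 3 reaches a number in this assay, compound 4 is expected to come in near the limit or just below it, with an expected step of an at least 1.4-fold lower number from compound 1 to compound 4 (0.15 log units; that floor lies within the scatter). The estimate for compound 4 is 35000 nM, in a range from 12000 nM to 100000 nM.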

Compound 4, half-maximal inhibitory concentration: 36400 nM
The estimate for compound 4 lay 1.0-fold (0.02 log units) below the measured number; the measured number falls inside the stated range.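

In this assay, among these compounds, compound 4 gives 36400 nM, so compound 3 is no longer the only thiourea-bearing compound with a measured number. Replacing 2-phenylphenyl with 4-methoxyphenyl on the amide-type nitrogen leaves the two thiourea-bearing compounds within the scatter of each other, with a 1.5-fold higher number from compound 3 to compound 4 (0.18 log units; within the scatter). Differences from the two compounds held at a limit, which is not a number, are known only as floors, an at least 1.3-fold lower number from compound 1 to compound 4 (0.13 log units; that floor lies within the scatter) and an at least 1.3-fold lower number from compound 2 to compound 4 (0.13 log units; that floor lies within the scatter), and the values behind them remain limits: the limit of > 50000 nM in this assay, at which 2 of the 4 values shown sit.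

The step between compound 1 and compound 2 cannot be read. On these data alone, it remains open whether a urea in place of the thiourea, or an amine or a carboxylic acid on the aromatic ring, would move the number in this assay beyond the scatter.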